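This account rests on a few compounds, and the source may have more. Where it says the series, first, only, none or still open, it means among the compounds named here.

Compound 1 `COc1cc(-c2nn(-c3cccc(NC(=O)c4ccc(Cl)c(C(F)(F)F)c4)c3)cc2-c2ccncc2)ccc1Cl` gives 23300 nM in a functional assay on COLO 205 cells (Homo sapiens) for inhibition, read by sulforhodamine B assay, with a stated time of 48 h; a lower number here means a stronger inhibitor of growth, a higher number a weaker inhibitor of growth.
Compound 2 `COc1cc(-c2nn(-c3cccc(NC(=O)Nc4cccc(C(F)(F)F)c4)c3)cc2-c2ccncc2)ccc1Cl` gives 1750 nM.
Compound 3 `COc1cc(-c2nn(-c3cccc(NC(=O)Nc4ccc(Cl)c(C(F)(F)F)c4)c3)cc2-c2ccncc2)ccc1Cl` gives 1540 nM.

Compound 3 has the lowest of the three numbers, though compound 2 stands within the usual scatter of it (a 1.1-fold lower number from compound 2 to compound 3 (0.06 log units; within the scatter)), while compound 1 lies well apart (a 15-fold lower number from compound 1 to compound 3 (1.18 log units; beyond the scatter)). Compound 4 `O=C(Nc1cccc(-n2cc(-c3ccncc3)c(-c3ccc(Cl)c(O)c3)n2)c1)Nc1ccc(Cl)c(C(F)(F)F)c1` differs from compound 3 in one place: hydrogen in place of methyl on an oxygen on an aromatic ring. Among the measured compounds shown here, no measured step touches this group: a 13-fold lower number from compound 1 to compound 2 (1.12 log units; beyond the scatter) and a 15-fold lower number from compound 1 to compound 3 (1.18 log units; beyond the scatter) both concern the group on the carbonyl carbon, and a 1.1-fold lower number from compound 2 to compound 3 (0.06 log units; within the scatter) a chloro on an aromatic carbon. With nothing to guide it, no step beyond the scatter is expected. Compound 4 is therefore estimated at 1600 nM, with a range from 500 nM to 5000 nM. This estimate means a 1.0-fold higher number from compound 3 to compound 4 (0.02 log units; within the scatter).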

Compound 4, concentration for total growth inhibition: 6750 nM
Estimate against measurement, compound 4: 4.2-fold (0.63 log units) below; measured number outside the range, above it.
By their numbers in this assay, from the lowest: compounds 3 and 2 (each within the scatter of the next); then compound 4; then compound 1.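

The step from methoxy to hydroxy is the only one shown at this position. In this assay it gives a 4.4-fold higher number from compound 3 to compound 4 (0.64 log units; beyond the scatter), so growth inhibition here responds to losing the methyl on this oxygen, and the compound becomes weaker. No measurement shown explains this loss. The compounds shown leave open how a longer chain on this oxygen, as in ethoxy, or an amine in place of the methoxy would compare. They also leave open whether the same change would have a similar effect in compound 2.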